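Second methoxy on the benzyl ring of compound 2

A few compounds are considered here, and "the series" means these few. Any claim that something is new, unique, unknown or untested is made for them only; others in the source may bear on it.

Compound 1 `COc1cccc(Cn2cnc3sc(-c4ccnc(Cl)c4)cc3c2=O)c1` gives 501 nM in an assay on isolated protein for inhibition of Rho-associated protein kinase 2 (Homo sapiens), read by radiometric assay and 33P incorporation, with a stated time of 40 min, in the presence of a further agent that is not named here; a lower number here means a stronger inhibitor, a higher number a weaker inhibitor. Compound 2 `COc1cccc(Cn2cnc3sc(-c4ccnc(N)c4)cc3c2=O)c1` gives 1 nM. For compound 3 `COc1cccc(Cn2cnc3sc(-c4ccc(N)nc4)cc3c2=O)c1` the reading is a limit of the assay, > 10000 nM.

Compound 2 gives the lowest number shown; the nearest is the step of a 500-fold lower number from compound 1 to compound 2 (2.70 log units; beyond the scatter). Compound 4 `COc1ccc(Cn2cnc3sc(-c4ccnc(N)c4)cc3c2=O)cc1OC` differs from compound 2 by methoxy in place of hydrogen on an aromatic carbon, ortho to a methoxy group and para to a large group. Going by the values given here, none of the measured steps touches that ring: a 500-fold lower number from compound 1 to compound 2 (2.70 log units; beyond the scatter), an at least 19-fold higher number from compound 1 to compound 3 (1.30 log units; beyond the scatter) and an at least 10000-fold higher number from compound 2 to compound 3 (4.00 log units; beyond the scatter) all alter the pyridine substituent, and all are large. They give no direct guide to the present change, so no step beyond the scatter is expected in this assay. Compound 4 is therefore estimated at 1.2 nM, with a range from 0.3 nM to 5 nM. The expected step is a 1.2-fold higher number from compound 2 to compound 4 (0.08 log units; within the scatter).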

Compound 4, half-maximal inhibitory concentration: 219 nM
For compound 4 the middle estimate is 180-fold (2.26 log units) below the measured one; measured number outside the range, above it.
By their numbers in this assay, from the lowest: compound 2; then compound 4; then compound 1. At a limit, above all of these: compound 3.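

In this assay, going by these compounds alone, the step is a 220-fold higher number from compound 2 to compound 4 (2.34 log units; beyond the scatter), so the benzyl ring, untouched by the earlier steps, also governs the reading. Compound 4 keeps the amino group of compound 2, so that group alone does not secure a low number on this core. The data shown give no explanation for this loss.

From the compounds shown here alone, whether the loss belongs to this position or to methoxy itself stays open. A fluorine or a hydroxy group at the same place would separate the two.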